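A Methoxyphenyl Analogue Expected to Track Its Neighbours

This account rests on a few compounds, and the source may have more. Where it says the series, first, only, none or still open, it means among the compounds named here.

Compound 1 `CCCCCCCCCCCCCCNC(=O)[C@H](CO)/N=C/c1ccc([N+](=O)[O-])cc1` bears a 4-nitrophenyl on the carbon with a double bond to nitrogen of the shared core. In a functional assay on cells (Homo sapiens) for cytotoxicity, read by MTT assay, with a stated time of 24 h (on this read-out higher numbers stand for weaker inhibition and lower numbers for stronger inhibition), compound 1 gives 217000 nM, the highest of the three numbers recorded. Compound 2 `CCCCCCCCCCCCCCNC(=O)[C@H](CO)/N=C/c1ccc(Cl)cc1` gives 27500 nM, and compound 3 `CCCCCCCCCCCCCCNC(=O)[C@H](CO)/N=C/c1cccc(O)c1` gives 32600 nM. Two measured steps start from compound 1: a 7.9-fold lower number from compound 1 to compound 2 (0.90 log units; beyond the scatter), and a 6.7-fold lower number from compound 1 to compound 3 (0.82 log units; beyond the scatter). Between the two lower compounds the difference is small: a 1.2-fold higher number from compound 2 to compound 3 (0.07 log units; within the scatter).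

Compound 4 `CCCCCCCCCCCCCCNC(=O)[C@H](CO)/N=C/c1cccc(OC)c1` differs from compound 1 in one place: 3-methoxyphenyl in place of 4-nitrophenyl on a carbon with a double bond to nitrogen. Within the data shown here, the closest precedent is the change to compound 3, where another substituted phenyl entered at the same carbon. Because a 6.7-fold lower number from compound 1 to compound 3 (0.82 log units; beyond the scatter) and likewise a 7.9-fold lower number from compound 1 to compound 2 (0.90 log units; beyond the scatter) both lowered the number by a modest but clear margin, a fall of comparable size is expected for compound 4, a 7.2-fold lower number from compound 1 to compound 4 (0.86 log units; beyond the scatter). Compound 4 is therefore estimated at 30000 nM, with a range from 12000 nM to 80000 nM.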

Compound 4, half-maximal inhibitory concentration: 31300 nM
Estimate against measurement, compound 4: 1.0-fold (0.02 log units) below; the range from low to high includes it.
By their numbers in this assay, from the lowest: compounds 2, 4 and 3 (each within the scatter of the next); then compound 1.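

In this assay, putting methyl in place of hydrogen on the oxygen of compound 3 leaves the number unmoved, a 1.0-fold lower number from compound 3 to compound 4 (0.02 log units; within the scatter), so at this position the free hydroxyl is not required for the level seen with compound 3. The 3-methoxyphenyl also sits level with the 4-chlorophenyl, a 1.1-fold higher number from compound 2 to compound 4 (0.06 log units; within the scatter), while the third step away from the 4-nitrophenyl, a 6.9-fold lower number from compound 1 to compound 4 (0.84 log units; beyond the scatter), confirms that among these four compounds only compound 1 stands apart. No supporting measurement bears on these results.

As far as these compounds go, whether the higher number of compound 1 goes with the nitro group itself or with its place on the ring stays open, and a 3-nitrophenyl or a 4-methoxyphenyl would separate the two. Also open, from the compounds shown here alone, is whether an aromatic amine or a carboxylic acid on the same ring would stay level with compounds 2, 3 and 4.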